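Methoxy for fluoro: notes on a thinly measured series

The source may hold more compounds than are shown below. What is called first, only, known or untested is meant among the compounds shown, and "the series" means these compounds.

Measured so far:
compound 1 `Oc1nc(-c2cccc(F)c2)nc2ccccc12`: "not active" (no number reported)
compound 2 `Oc1nc(-c2ccc3ccccc3c2)nc2ccccc12`: 19.1 ug/mL

In a functional assay on HCT-8 cells (Homo sapiens) (a lower number here means that less compound is needed, a higher number that more compound is needed for the effect), compound 1 stands at "not active" (no number reported), with no number reported, so it has no place on the scale and any step away from it can only be described loosely. The sole numerical reference in the series is compound 2 at 19.1 ug/mL.

Compound 3 `COc1cccc(-c2nc(O)c3ccccc3n2)c1` keeps the core of compound 1 and differs in one place: methoxy in place of fluoro on an aromatic carbon. Methoxy takes the place of fluoro on an aromatic carbon of a six-membered aromatic ring of carbon only, meta to a large group. Going by the values given here, no measured pair shows what this exchange does. In this assay a modest step is expected, if any, in the direction of a measurable effect, and compound 3 may well return no number either. If a number is obtained, the expected value for compound 3 is 25 ug/mL, within an estimated range of 10 ug/mL to 60 ug/mL.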

Compound 3, concentration for half-maximal effect: > 20 ug/mL
Compound 3 ended at the assay's limit; the forecaster's own chance of this, stated with the estimate: 50%; the middle value is on the limit's open side.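

In this assay compound 3 gives > 20 ug/mL, which is a limit of the assay and not a number. Compound 1 has no number either, so no step can be read between compound 1 and compound 3. The compounds shown leave open whether methoxy in place of fluoro changes the effect at all.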